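The source may hold more compounds than are shown below. What is called first, only, known or untested is meant among the compounds shown, and "the series" means these compounds.

Measured compounds in an assay for inhibition of histone acetyltransferase KAT2B (Homo sapiens), read by TR-FRET, with a stated time of 10 min, tested at 50 uM; a lower number here means less inhibition, a higher number more inhibition at the concentration tested (going by the name of the read-out):
compound 1, `O=C(O)CCCCCN1C(=O)/C(=C2/C(=O)Nc3ccccc32)SC1=S`, gives 9%;
compound 2, `COC(=O)CCN1C(=O)/C(=C/c2cc(OC)ccc2OC)SC1=S`, gives 8%;
compound 3, `COC(=O)CCCCCN1C(=O)/C(=C2/C(=O)N(Cc3ccc(C)cc3)c3ccccc32)SC1=S`, gives 8%.

All three numbers sit close together. Compound 2 reads level with compound 3, the two of them together at the lower end of the three readings, and compound 1 gives a number that differs from that of compound 2 only within the usual scatter of this assay. Nothing among the three readings separates one compound from another beyond that scatter.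

The step considered here leads from compound 2 to compound 4, `COC(=O)CCCCCN1C(=O)/C(=C/c2cc(OC)ccc2OC)SC1=S`, which has not yet been measured in this assay. The change is 3-(methoxycarbonyl)propyl in place of methoxycarbonyl on a saturated chain carbon, two bonds along the chain from an amide-type nitrogen in a ring. Compounds 1 and 3 both carry a chain of the longer kind in the same region of the shared core, and their readings stand beside that of compound 2. For the measured compounds named here, no step between measured compounds has been worked out, so the expectation rests on that neighbourhood alone. The expected step, no change at the digits printed from compound 2 to compound 4 (within the scatter), is one that stays within the scatter, in no particular direction. Compound 4 is therefore estimated at 8%, with a range from -2% to 20%.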

Compound 4, a percentage reported as inhibition, at one concentration (the size of the read-out at that concentration, not a potency): 21%
Estimate against measurement, compound 4: 13 percentage points below; measured number outside the range, above it.
By their numbers in this assay, from the lowest: compounds 2, 3 and 1 (each within the scatter of the next); then compound 4.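

In this assay, 3-(methoxycarbonyl)propyl in place of methoxycarbonyl on a saturated chain carbon, two bonds along the chain from an amide-type nitrogen in a ring, gives a number 13 percentage points higher from compound 2 to compound 4 (beyond the scatter), so with the rest of the structure unchanged, this position does respond to the change. The earlier compounds shown here could not show this: their numbers lie within the scatter of one another, and compounds 1 and 3, though they carry a chain of the longer kind, differ from compound 4 in more than one place, so the finding rests on this single pair and makes no general rule about chain length. Nothing among the data shown explains why the number moves at this position.

On these data alone, it stays open whether the reading follows the length of the chain or needs the methoxycarbonyl end, which a carboxylic acid or an amine at the chain end of compound 4 would help to separate. As far as these compounds go, it is equally open how a chain of intermediate length or a longer chain would read, and so whether the step reflects a steady trend or a particular length.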